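Amide aryl swap in the nitrophenyl series

The compounds below may be only part of what the source reports. "The series", "measured", "known", "first", "only" and "open" are said of these compounds alone.

Among the compounds with values here, compound 2 `O=C(Nn1c(-c2cccc([N+](=O)[O-])c2)nc2c(-c3ccc(F)cc3)n[nH]c2c1=O)c1cccnc1` stands lowest of the two numbers measured so far. In a functional assay on SK-OV-3 cells (Homo sapiens) for cytotoxicity, read by sulforhodamine B assay, with a stated time of 2 days, tested at 100 uM (on this read-out lower numbers stand for less inhibition and higher numbers for more inhibition at the one concentration tested (going by the name of the read-out)), compound 2 gives 19.3%, while compound 1 `O=C(Nn1c(-c2cccc([N+](=O)[O-])c2)nc2c(-c3ccc(Cl)cc3)n[nH]c2c1=O)c1cccnc1` gives 30.2%. Within the data shown here, the single measured step, a number 10.9 percentage points lower from compound 1 to compound 2 (beyond the scatter), is a fluoro in place of chloro change and does not touch the carbonyl-bound ring. Compound 3 `O=C(Nn1c(-c2cccc([N+](=O)[O-])c2)nc2c(-c3ccc(F)cc3)n[nH]c2c1=O)c1ccccc1` differs from compound 2 by phenyl in place of pyridin-3-yl on a carbonyl carbon. Among the measured compounds shown here, no measured step bears on this kind of exchange, so the halogen step gives no guide to the size or direction of the coming one; what the two measured numbers show is only that the series so far sits in a modest band. The expectation for compound 3 is accordingly no step beyond the scatter, a number 0.7 percentage points higher from compound 2 to compound 3 (within the scatter). Compound 3 is estimated at 20% in this assay, with a range from 5% to 40%.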

Compound 3, a percentage reported as inhibition, at one concentration (the size of the read-out at that concentration, not a potency): 77.7%
Beside the measured number, compound 3's estimate is 57.7 percentage points below it; measured number outside the range, above it.
By their numbers in this assay, from the lowest: compound 2; then compound 1; then compound 3.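

The carbonyl-bound ring, untouched by the halogen exchange, is where the larger change in this assay appears among the compounds shown: phenyl in place of pyridin-3-yl on a carbonyl carbon gives a number 58.4 percentage points higher from compound 2 to compound 3 (beyond the scatter) with the rest of the compound unchanged. That step exceeds the modest halogen step, a number 10.9 percentage points lower from compound 1 to compound 2 (beyond the scatter) in the same assay, and it goes with the loss of the ring nitrogen and of the hydrogen-bond acceptor counted for pyridin-3-yl. No supporting measurement is available to explain the size of this step.

Going by these compounds, whether the same exchange would give a similar rise in the chloro compound 1 remains open. Also open, on these data alone, is how a pyridin-4-yl ring, or a phenyl ring carrying a carboxylic acid or a dimethylamino group, would read on the same carbonyl carbon.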